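Compound 2 to Compound 3: One Chain Rearranged

The source may hold more compounds than are shown below. What is called first, only, known or untested is meant among the compounds shown, and "the series" means these compounds.

Measured so far:
compound 1, `Clc1ccc(OCc2nc3c(OCCC4CCNCC4)cccc3n2CCCC2CCCNC2)cc1`, 7 nM 
compound 2, `Clc1ccc(OCc2nc3ccccc3n2CCC2CCCCN2)cc1`, 7860 nM 

Of the compounds shown here, two have been measured in an assay on isolated protein for binding affinity to Neuropeptide Y receptor type 1 (Homo sapiens); on this read-out higher numbers stand for weaker inhibition and lower numbers for stronger inhibition. Compound 1 gives 7 nM and stands as the lower of the two numbers. Compound 2 gives 7860 nM, the higher of the two numbers; the gap to compound 1 lies well beyond the scatter. Among the measured compounds shown here, compound 1 carries additional groups that compound 2 lacks, and no single-point step between them is available, so their two values can only be set side by side.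

Compound 3, `Clc1ccc(OCc2nc3ccccc3n2CCCN2CCCCC2)cc1`, is not yet measured. It differs from compound 2 in one place: (piperidin-1-yl)methyl in place of piperidin-2-yl on a saturated chain carbon, two bonds along the chain from an aromatic nitrogen.

Whether the shared core with this rearranged chain gains or loses is not settled by any measured pair. Starting from the weak value of compound 2, the expected step of a 2.0-fold lower number from compound 2 to compound 3 (0.29 log units; within the scatter) is small, within or just beyond the scatter, with no firm direction. Compound 3 is therefore estimated at 4000 nM, in a range from 600 nM to 20000 nM.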

Compound 3, inhibition constant: 7020 nM
The estimate for compound 3 lay 1.8-fold (0.24 log units) below the measured number; measured number inside the range.
By their numbers in this assay, from the lowest: compound 1; then compounds 3 and 2 (each within the scatter of the next).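

In this assay, the change reads a 1.1-fold lower number from compound 2 to compound 3 (0.05 log units; within the scatter), so at this position on a saturated chain carbon, two bonds along the chain from an aromatic nitrogen, the two chains cannot be told apart. The same difference, cut one bond further out, is 2-(piperidin-2-yl)ethyl to 3-(piperidin-1-yl)propyl, and this first single-point comparison in the series shows that this rearrangement of the chain leaves the read-out within the usual scatter. It also takes the count from 1 hydrogen-bond donor on piperidin-2-yl to 0 hydrogen-bond donors on (piperidin-1-yl)methyl without a change that can be read, though no measurement at hand gives a reason for this outcome.

The compounds shown leave open whether another group at this place, such as a morpholine ring, a primary amine or a longer chain, would move the number beyond the scatter. Among the compounds shown here, they also leave open which of the several structural differences goes with the much lower number of compound 1, 7 nM, since no single-point step connects it to either of the other two compounds.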